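The compounds below may be only part of what the source reports. "The series", "measured", "known", "first", "only" and "open" are said of these compounds alone.

Compound 1 `O=C(COc1cccc2ccccc12)N/N=C/c1cccc(O)c1`: 100 ug/mL. Compound 2 `C/C(=N\NC(=O)COc1cccc2ccccc12)c1ccc(C#N)cc1Br`: 20 ug/mL.

In an ADME assay on HEL cells (Homo sapiens) for cytotoxicity (a lower number here means that less compound is tolerated, a higher number that more compound is tolerated), compound 2 gives 20 ug/mL, the lowest of the two numbers recorded, while compound 1 gives 100 ug/mL, a gap beyond the usual scatter. Compound 3 `C/C(=N\NC(=O)COc1cccc2ccccc12)c1ccc([N+](=O)[O-])cc1` remains to be measured. It differs from compound 2 in one place: 4-nitrophenyl in place of 2-bromo-4-cyanophenyl on a carbon with a double bond to nitrogen. For the measured compounds named here, no measured pair shows the effect of such a change, so the size of the step in this assay is uncertain; a modest rise, toward more compound tolerated, is expected, though a step within the scatter is also plausible. For compound 3 the estimate is 30 ug/mL, within 10 ug/mL to 100 ug/mL. The expected step is a 1.5-fold higher number from compound 2 to compound 3 (0.18 log units; within the scatter).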

Compound 3, minimum cytotoxic concentration: 100 ug/mL
The estimate for compound 3 lay 3.3-fold (0.52 log units) below the measured number, within the range that was stated.
By their numbers in this assay, from the lowest: compound 2; then compounds 1 and 3 (each within the scatter of the next).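

In this assay, the group on the carbon with a double bond to nitrogen proves able to move the result: 4-nitrophenyl in place of 2-bromo-4-cyanophenyl brings a 5.0-fold higher number from compound 2 to compound 3 (0.70 log units; beyond the scatter). For the compounds shown here, this is the first one-place comparison available, and it shows more compound tolerated with the rest of the structure unchanged. Nothing available explains this step. As far as these compounds go, the change alters several features at once, so the separate contributions of the bromine, the nitrile and the nitro group remain unknown. From the compounds shown here alone, how an amine or a carboxylic acid on that phenyl ring would read also remains open.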